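Biphenyl-thiadiazole amines: N-substituent steps in the mouse assay

The compounds below may be only part of what the source reports. "The series", "measured", "known", "first", "only" and "open" are said of these compounds alone.

Measured so far:
compound 1 `CC(C)NCc1nnc(-c2ccccc2-c2ccccc2)s1`, 23 mg/kg
compound 2 `c1ccc(CNCc2nnc(-c3ccccc3-c3ccccc3)s2)cc1`, 37 mg/kg
compound 3 `NCc1nnc(-c2ccccc2-c2ccccc2)s1`, 20 mg/kg

These are doses in a functional assay on the whole organism with Mus musculus as the target; on this read-out higher numbers stand for an effect only at larger amounts of compound and lower numbers for an effect already at smaller amounts. Compound 3 is not separated from its two neighbours beyond the scatter: a 1.2-fold lower number from compound 1 to compound 3 (0.06 log units; within the scatter) and a 1.9-fold lower number from compound 2 to compound 3 (0.27 log units; within the scatter), so the three compounds sit at one level. Compound 4 `Cc1ccccc1NCc1nnc(-c2ccccc2-c2ccccc2)s1` differs from compound 3 by 2-methylphenyl in place of hydrogen on an amine nitrogen. Among the compounds with values here, the steps that bear on it are those at the same nitrogen, isopropyl and benzyl against hydrogen, both within the scatter. No step beyond the scatter is therefore expected for a 1.3-fold higher number from compound 3 to compound 4 (0.10 log units; within the scatter) in this assay, and no direction is favoured. Compound 4 is estimated at 25 mg/kg, with a range from 12 mg/kg to 50 mg/kg.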

Compound 4, dose for half-maximal effect: > 200 mg/kg
Compound 4 was reported as a limit (the forecaster's own chance of this, stated with the estimate: 10%); middle value at least 8.0-fold (0.90 log units) from the limit.
By their numbers in this assay, from the lowest: compounds 3, 1 and 2 (each within the scatter of the next). At a limit, above all of these: compound 4.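

Compound 4 stands only as a limit in this assay: the limit of > 200 mg/kg in this assay, at which 1 of the 4 values shown sits.
Hydrogen, isopropyl and benzyl on the amine nitrogen stayed within the scatter of one another, whereas 2-methylphenyl gives the first steps beyond it: (an at least 10-fold higher number from compound 3 to compound 4 (1.00 log units; beyond the scatter)), (an at least 8.6-fold higher number from compound 1 to compound 4 (0.93 log units; beyond the scatter)) and (an at least 5.4-fold higher number from compound 2 to compound 4 (0.73 log units; beyond the scatter)). This position therefore accepts some carbon substituents without a step beyond the scatter, but not all of them.

From the compounds shown here alone, the true size of these steps remains open, as the limit sets only their lower bound. Also open, going by these compounds, is whether an unsubstituted phenyl on the same nitrogen would sit with compound 4 or with compound 2.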